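Halogen position swap on the chain-borne phenyl: compound 3

The source may report more compounds than this note shows. Statements on the series, on what has been measured and on what is new or still open speak of the compounds shown alone.

Of the compounds shown here, two have been measured so far; both share one core and differ only at the phenyl on the chain. Compound 1 `C/C(=N\NC(=O)/C(C#N)=C/c1ccc(O)cc1)c1c(O)c2ccc(O)cc2oc1=O` carries a hydroxy there, and in a functional assay on MCF7 cells (Homo sapiens) for cytotoxicity, read by MTT assay, with a stated time of 24 h (on this read-out lower numbers stand for stronger inhibition and higher numbers for weaker inhibition), compound 1 gives 7320 nM. Compound 2 `C/C(=N\NC(=O)/C(C#N)=C/c1ccc(Br)cc1)c1c(O)c2ccc(O)cc2oc1=O` has bromo in place of hydroxy on an aromatic carbon, and in this assay compound 2 gives 9850 nM. The step of a 1.3-fold higher number from compound 1 to compound 2 (0.13 log units; within the scatter) is within the scatter, so the two values cannot be ordered with confidence. On the numbers shown, compound 2 has the highest value of the two, by a margin that is within the scatter.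

Compound 3 `C/C(=N\NC(=O)/C(C#N)=C/c1ccccc1Cl)c1c(O)c2ccc(O)cc2oc1=O` is the next candidate: 2-chlorophenyl in place of 4-bromophenyl on a double-bonded chain carbon bound to a double-bonded chain carbon. Going by the values given here, the only measured step touches the same ring, and it was a 1.3-fold higher number from compound 1 to compound 2 (0.13 log units; within the scatter), a change of substituent that left the read-out essentially unmoved. Among the compounds with values here, no measured step speaks to exchanging bromine for chlorine or to the shift of position. For this assay the expectation is therefore no step beyond the scatter, with a broad range. Compound 3 is estimated at 9000 nM, between 4000 nM and 20000 nM. The expected step is a 1.1-fold lower number from compound 2 to compound 3 (0.04 log units; within the scatter).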

Compound 3, half-maximal inhibitory concentration: 8880 nM
Estimate against measurement, compound 3: 1.0-fold (0.01 log units) above, and the stated range covers the measured number.
By their numbers in this assay, from the lowest: compounds 1, 3 and 2 (each within the scatter of the next).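

Working notes on the chain-borne phenyl: in this assay, replacing 4-bromophenyl with 2-chlorophenyl on a double-bonded chain carbon bound to a double-bonded chain carbon gives a small step (a 1.1-fold lower number from compound 2 to compound 3 (0.05 log units; within the scatter)), and replacing 4-hydroxyphenyl with 2-chlorophenyl gives another (a 1.2-fold higher number from compound 1 to compound 3 (0.08 log units; within the scatter)). The earlier pair covered only an exchange of substituent on the 4-substituted phenyl, whereas compound 3 changes both the halogen and its place on the ring, and the read-out still stays within the scatter, so the three aryl groups cannot be ordered in this assay. No supporting data bear on the reason for this flat result.

Because the halogen and its place on the ring change together in compound 3, the contribution of each cannot be read separately from these compounds. Also open, on these data alone, is whether an amine, a carboxylic acid or a longer chain at this place, or any change elsewhere on the shared core, would move the number beyond the scatter.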